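A few compounds are considered here, and "the series" means these few. Any claim that something is new, unique, unknown or untested is made for them only; others in the source may bear on it.

Measured compounds:
- compound 1, `CC(C)C[C@@H](/C=C/C(Cc1ccccc1)(Cc1ccccc1)C(=O)NC1CC(C)(C)NC(C)(C)C1)NC(=O)OC(C)(C)C`, in a physicochemical assay for lipophilicity (on this read-out higher numbers stand for higher lipophilicity and lower numbers for lower lipophilicity), compound 1 gives 7.2
- compound 2, `CC1(C)CC(NC(=O)C(/C=C/[C@@H](NC(=O)OC(C)(C)C)c2ccc(F)cc2)(Cc2ccc(F)cc2)Cc2ccc(F)cc2)CC(C)(C)N1`, in this assay compound 2 gives 7.9
- compound 3, `CC1(C)CC(NC(=O)C(/C=C/[C@H](NC(=O)OC(C)(C)C)c2ccc(F)cc2)(Cc2ccc(F)cc2)Cc2ccc(F)cc2)CC(C)(C)N1`, in this assay compound 3 gives 7.9

Compound 3 stands level with compound 2 at the digits given, the two together the highest of the three numbers; compound 1 lies lower by an amount beyond the scatter. Going by the values given here, the only step measured between two compounds that differ in one place is no change at the digits printed from compound 2 to compound 3 (within the scatter), which rests on the fact that compounds 2 and 3 differ only in the configuration as drawn and shows no change within the scatter.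

The next compound, compound 4, is `CC1(C)CC(NC(=O)C(/C=C/[C@H](NC(=O)OC(C)(C)C)c2ccoc2)(Cc2ccc(F)cc2)Cc2ccc(F)cc2)CC(C)(C)N1`. Relative to compound 3 the change is furan-3-yl in place of 4-fluorophenyl on a saturated chain carbon bound to an amide-type nitrogen and a double-bonded chain carbon. Among the compounds with values here, none of the measured steps bears on this change: the step from compound 2 to compound 3 alters configuration only, and compound 1 differs from compound 3 in several places at once, so the gap between them cannot be assigned to any single group. The expectation therefore rests on the structural change alone. A six-membered carbon-only aromatic ring carrying fluorine gives way to a smaller five-membered ring with one oxygen, and a downward step in this assay beyond the scatter is expected, estimated as a number 0.90 log units lower from compound 3 to compound 4 (beyond the scatter). Compound 4 is thus estimated at 7, with a range from 6.4 to 7.6.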

Compound 4, partition coefficient: 6
The estimate for compound 4 lay 1.00 log units above the measured number, outside the stated range (below it).
By their numbers in this assay, from the lowest: compound 4; then compound 1; then compounds 2 and 3 (each within the scatter of the next).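

In this assay, furan-3-yl in place of 4-fluorophenyl on a saturated chain carbon bound to an amide-type nitrogen and a double-bonded chain carbon gives a number 1.90 log units lower from compound 3 to compound 4 (beyond the scatter) as a large step in a single place. Going by these compounds alone, the read-out at this carbon therefore depends on the group it carries, which the only earlier step there could not show, since no change at the digits printed from compound 2 to compound 3 (within the scatter) involves configuration alone. No measurement shown here accounts for the size of the new step.

From the compounds shown here alone, with a single replacement of the group at this carbon, it remains open whether the step follows from the absence of fluorine, the smaller ring or the ring oxygen, and phenyl, thiophen-3-yl or pyridin-3-yl at the same place would help to separate these. Going by these compounds, it also remains open whether the two drawn configurations at this carbon, level in the 4-fluorophenyl pair, would stay level with furan-3-yl in place.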